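Ring substitution on the thioether arm of the nucleoside series

The source may hold more compounds than are shown below. What is called first, only, known or untested is meant among the compounds shown, and "the series" means these compounds.

Three measured compounds share one core and differ only in the aryl group on a saturated chain carbon bound to a sulfur. Compound 1 `OC[C@H]1O[C@@H](n2cnc3c(SCc4ccccc4Br)ncnc32)[C@H](O)[C@@H]1O` carries a 2-bromophenyl and gives 151 nM in an assay on isolated protein for inhibition of Equilibrative nucleoside transporter 1 (Homo sapiens); on this read-out higher numbers stand for weaker inhibition and lower numbers for stronger inhibition. Compound 2 `OC[C@H]1O[C@@H](n2cnc3c(SCc4ccc(Br)cc4)ncnc32)[C@H](O)[C@@H]1O` carries a 4-bromophenyl and gives 11.5 nM in this assay. Compound 3 `Cc1cccc(CSc2ncnc3c2ncn3[C@@H]2O[C@H](CO)[C@@H](O)[C@H]2O)c1` carries a 3-methylphenyl and gives 16.2 nM in this assay; its number is the second highest of the three, with compound 2 nearest and compound 1 furthest.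

The steps: a 13-fold lower number from compound 1 to compound 2 (1.12 log units; beyond the scatter); a 9.3-fold lower number from compound 1 to compound 3 (0.97 log units; beyond the scatter); a 1.4-fold higher number from compound 2 to compound 3 (0.15 log units; within the scatter).

Compound 4 `OC[C@H]1O[C@@H](n2cnc3c(SCc4ccc(Cl)c(Cl)c4)ncnc32)[C@H](O)[C@@H]1O` is the next member: 3,4-dichlorophenyl in place of 3-methylphenyl on a saturated chain carbon bound to a sulfur. The new ring carries chlorine where compound 2 carries bromine and where compound 3 carries methyl, and both of those groups gave the lower numbers of the set. The step from compound 2 to compound 3 lies within the scatter, so no change beyond the scatter is expected here, if anything a slightly lower number.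

For compound 4 the expected value in this assay is 12 nM, with a range from 5 nM to 35 nM, which corresponds to an expected 1.4-fold lower number from compound 3 to compound 4 (0.13 log units; within the scatter).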

Compound 4, inhibition constant: 12.6 nM
For compound 4 the middle estimate is 1.1-fold (0.02 log units) below the measured one, and the stated range covers the measured number.
By their numbers in this assay, from the lowest: compounds 2, 4 and 3 (each within the scatter of the next); then compound 1.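

In this assay, changing the ring at this position on a saturated chain carbon bound to a sulfur from 3-methylphenyl to 3,4-dichlorophenyl makes no change that can be read (a 1.3-fold lower number from compound 3 to compound 4 (0.11 log units; within the scatter)), and the same holds for the comparison with the 4-bromophenyl ring (a 1.1-fold higher number from compound 2 to compound 4 (0.04 log units; within the scatter)). A ring with 2 chlorine atoms therefore sits with the singly substituted rings of compound 2 and compound 3, while the 2-bromophenyl ring of compound 1 stays apart from it (a 12-fold lower number from compound 1 to compound 4 (1.08 log units; beyond the scatter)), so compound 1 remains the only one of the four outside this group. Nothing available explains why the 2-bromophenyl ring stands apart from the other three rings.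

Open, from the compounds shown here alone, is whether the number of compound 1 goes with bromine in particular or also appears with other groups named in the same way, such as 2-chlorophenyl or 2-methylphenyl. Also open, going by these compounds, is how this position responds to a ring bearing an amine or a carboxylic acid, or to a longer chain between the sulfur and the ring.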